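Dropping the acetamido group from the piperidine ring

A few compounds are considered here, and "the series" means these few. Any claim that something is new, unique, unknown or untested is made for them only; others in the source may bear on it.

- compound 1: `CNC1CCN(c2ncnc3[nH]cc(-c4cccc(Cl)c4)c23)CC1`, 148 nM
- compound 2: `CC(=O)NC1CCN(c2ncnc3[nH]cc(-c4cccc(Cl)c4)c23)CC1`, 26 nM

Among the measured compounds shown here, in an assay for inhibition of serine/threonine-protein kinase 4 (Homo sapiens), read by luminescence and ADP-Glo, in the presence of a further agent that is not named here (on this read-out lower numbers stand for stronger inhibition and higher numbers for weaker inhibition), compound 2 gives the lower of the two numbers so far; its nearest neighbour is compound 1, and the one step measured, a 5.7-fold lower number from compound 1 to compound 2 (0.76 log units; beyond the scatter), is the change of acetyl in place of methyl on an amine nitrogen. Compound 3, `Clc1cccc(-c2c[nH]c3ncnc(N4CCCCC4)c23)c1`, carries no group at all on that saturated ring carbon: hydrogen in place of acetamido on a saturated ring carbon. For the measured compounds named here, no measured step covers this change directly. Going by the values given here, the only step on hand shows that the acetamido group went with a lower number than the methylamino group, so taking it away removes that gain, and the number is expected to rise again, perhaps to near or beyond where compound 1 stands. The step from compound 2 to compound 3 in this assay is therefore estimated as a 12-fold higher number from compound 2 to compound 3 (1.06 log units; beyond the scatter). For compound 3 the estimated value is 300 nM, with a range from 80 nM to 1200 nM.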

Compound 3, half-maximal inhibitory concentration: 48 nM
Estimate against measurement, compound 3: 6.3-fold (0.80 log units) above; measured number below the stated range.
By their numbers in this assay, from the lowest: compounds 2 and 3 (each within the scatter of the next); then compound 1.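

Putting bare hydrogen on this saturated ring carbon in this assay gives a step within the scatter (a 1.8-fold higher number from compound 2 to compound 3 (0.27 log units; within the scatter)), so the acetamido group is not needed for a number in this range. Methylamino, by contrast, stands apart from the unsubstituted ring (a 3.1-fold lower number from compound 1 to compound 3 (0.49 log units; beyond the scatter)), which means the earlier gain with acetyl reads better as methylamino going with a higher number than the bare ring than as acetamido adding anything of its own. The data offer no measurement that explains why these groups differ.

On these data alone, whether any group on this carbon can give a number clearly lower than those of compound 2 and compound 3 stays open, for example a hydroxyl, a carboxylic acid or a longer chain. A plain primary amine at the same place would show whether the number of methylamino belongs to the amine nitrogen itself.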